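The source may hold more compounds than are shown below. What is called first, only, known or untested is meant among the compounds shown, and "the series" means these compounds.

Compound 1 `COc1cc(OC)c(C(=O)/C=C/c2ccc(Cl)cc2)c(OC)c1`, compound 2 `COc1cc(OC)c(C(=O)/C=C/c2ccc(Br)cc2)c(OC)c1` and compound 3 `COc1cc(OC)c(C(=O)/C=C/c2ccccc2)c(OC)c1` share one core and differ only in a single group on an aromatic carbon. In a functional assay on Caco-2 cells (Homo sapiens) for cytotoxicity, with a stated time of 48 h (on this read-out higher numbers stand for weaker inhibition and lower numbers for stronger inhibition), compound 1 gives 5700 nM, compound 2 gives 6800 nM and compound 3 gives 5800 nM. Among the measured compounds shown here, the number for compound 3 sits among those of its two neighbours, within the scatter of both, so no compound can be called stronger or weaker than another. The three steps among them are all small: a 1.2-fold higher number from compound 1 to compound 2 (0.08 log units; within the scatter), a 1.0-fold higher number from compound 1 to compound 3 (0.01 log units; within the scatter) and a 1.2-fold lower number from compound 2 to compound 3 (0.07 log units; within the scatter). Each swaps one group on the same aromatic ring for another, and none moves the number beyond the scatter.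

Compound 4 `COc1cc(OC)c(C(=O)/C=C/c2ccccc2OC)c(OC)c1` is the next step from compound 3: methoxy in place of hydrogen on an aromatic carbon. The change again sits on an aromatic carbon of a six-membered aromatic ring of carbon only, like the three measured swaps, and those swaps left the number essentially unchanged. A step of about no change at the digits printed from compound 3 to compound 4 (within the scatter) is therefore expected in this assay, that is, none beyond the scatter. For compound 4 the estimate is 5800 nM, within a range of 2900 nM to 11600 nM.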

Compound 4, half-maximal inhibitory concentration: 4500 nM
For compound 4 the middle estimate is 1.3-fold (0.11 log units) above the measured one; measured number inside the range.
By their numbers in this assay, from the lowest: compounds 4, 1, 3 and 2 (each within the scatter of the next).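

In this assay, among the compounds shown here, methoxy is the first change here that brings in more than a single atom, and it sits ortho to a large group, yet the outcome is a 1.3-fold lower number from compound 3 to compound 4 (0.11 log units; within the scatter). The steps to the same 2-methoxyphenyl compound from the two halogen-bearing compounds, a 1.5-fold lower number from compound 2 to compound 4 (0.18 log units; within the scatter) and a 1.3-fold lower number from compound 1 to compound 4 (0.10 log units; within the scatter), also stay inside the scatter, so phenyl, 4-chlorophenyl, 4-bromophenyl and 2-methoxyphenyl cannot be told apart in this assay. No measurement shown bears on the reason for this flat result.

Going by these compounds, it remains open whether a different kind of group on this ring, such as an amine or a carboxylic acid, would move the number beyond the scatter. On these data alone, it also remains open whether changing the methoxy groups on the shared core would do so.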